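The source may report more compounds than this note shows. Statements on the series, on what has been measured and on what is new or still open speak of the compounds shown alone.

- Compound 1 `C=CCNC(=C\C(=O)/C=C/c1ccc(O)c(OC)c1)/C=C/c1ccc(O)c(OC)c1`: > 25000 nM
- Compound 2 `COc1cc(/C=C/C(=O)/C=C(/C=C/c2ccc(O)c(OC)c2)NCC(C)C)ccc1O`: > 25000 nM

Both entries come from a functional assay on Caco-2 cells (Homo sapiens) for inhibition, read by MTT assay, with a stated time of 72 h (a higher number here means a weaker inhibitor, a lower number a stronger inhibitor), and both are limits of the assay, not numbers. Compound 2 stands at a limit, reported as > 25000 nM. Compound 1 stands at a limit too, reported as > 25000 nM. The evidence so far amounts to one observation: the limit of > 25000 nM in this assay, at which 2 of the 2 values shown sit. For the measured compounds named here, the only measured step, a step that the two limits leave unreadable from compound 1 to compound 2, has no readable size, so it offers no scale for a change at this place.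

Compound 3 `CCCCNC(=C\C(=O)/C=C/c1ccc(O)c(OC)c1)/C=C/c1ccc(O)c(OC)c1` keeps the shared core and alters only the chain on the nitrogen: propyl in place of isopropyl on a saturated chain carbon bound to an amine nitrogen. Seen one bond further out, the isobutylamino group of compound 2 becomes the butylamino group of compound 3.

No step beyond the usual scatter is expected in this assay, in either direction, because compound 2 gives > 25000 nM. The assay will most likely report only a limit again. The expected step is a step that the limit leaves unreadable from compound 2 to compound 3. For compound 3 the estimate is 30000 nM, with an expected range of 15000 nM to 60000 nM.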

Compound 3, half-maximal inhibitory concentration: > 25000 nM
Compound 3: only a limit was reported; the forecaster's own chance of this, stated with the estimate: 75%; the middle value does not contradict the limit.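

In this assay compound 3 gives > 25000 nM, a limit of the assay and not a number. The steps to compound 3 from compound 1 and from compound 2 cannot be read, and the evidence remains one observation: the limit of > 25000 nM in this assay, at which 3 of the 3 values shown sit.

The compounds shown leave open whether changing the chain on the nitrogen alters inhibition in this assay at all.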